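A few compounds are considered here, and "the series" means these few. Any claim that something is new, unique, unknown or untested is made for them only; others in the source may bear on it.

In a functional assay on JeKo-1 cells (Homo sapiens) for inhibition, read by luminescence and CellTiter-Glo, with a stated time of 72 h (on this read-out lower numbers stand for stronger inhibition and higher numbers for weaker inhibition), compound 2 `C=CC(=O)Nc1cccc(Cn2nc(-c3ccc(Oc4ccccc4)cc3)cc2C(=O)OCC)c1` gives 7600 nM, the lowest of the two numbers in hand. Among the compounds with values here, its only measured neighbour, compound 1 `C/C=C/C(=O)Nc1ccc(Cn2nc(-c3ccc(Oc4ccccc4)cc3)cc2C(=O)OCC)cc1`, gives in this assay 52500 nM, and the step of a 6.9-fold lower number from compound 1 to compound 2 (0.84 log units; beyond the scatter) is the single measured change.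

Compound 3 `CCOC(=O)c1cc(-c2ccc(Oc3ccccc3)cc2)nn1Cc1ccc(NC(=O)CCl)cc1` is not yet measured in this assay. Against compound 2 it differs in one place: 4-(((chloromethyl)carbonyl)amino)phenyl in place of 3-((vinylcarbonyl)amino)phenyl on a saturated chain carbon bound to an aromatic nitrogen. The change partly retraces the measured step: the amide returns to the 4-position of the phenyl as in compound 1, while the chloromethyl amide is a group not seen in either measured compound. Within the data shown here, the only step that bears on it is a 6.9-fold lower number from compound 1 to compound 2 (0.84 log units; beyond the scatter), which ran toward a lower number from compound 1 to compound 2; reversing the substitution pattern is expected to give part of that back, with the unknown contribution of the chloromethyl amide leaving the size uncertain. A modest rise in the number is expected, a 2.6-fold higher number from compound 2 to compound 3 (0.42 log units; beyond the scatter). For compound 3 the estimate is 20000 nM, with a range of 5000 nM to 80000 nM.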

Compound 3, half-maximal inhibitory concentration: 400 nM
For compound 3 the middle estimate is 50-fold (1.70 log units) above the measured one; measured number outside the range, below it.
By their numbers in this assay, from the lowest: compound 3; then compound 2; then compound 1.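

In this assay, compound 1 and compound 3 differ only in the group on the carbonyl carbon, and chloromethyl in place of prop-1-en-1-yl gives a 130-fold lower number from compound 1 to compound 3 (2.12 log units; beyond the scatter), so this one group moves the number further than the earlier step did. The step of a 19-fold lower number from compound 2 to compound 3 (1.28 log units; beyond the scatter) runs against the direction of the first measured change: with 4-(((chloromethyl)carbonyl)amino)phenyl on the saturated chain carbon, compound 3 has the lowest number of the three, so a 4-substituted phenyl does not by itself carry a high number. No measurement in hand explains this gain.

As far as these compounds go, the step from compound 2 to compound 3 changes the place of the amide and the group on its carbonyl carbon together, so the share of each stays unknown; 3-(((chloromethyl)carbonyl)amino)phenyl and 4-((vinylcarbonyl)amino)phenyl would separate them. From the compounds shown here alone, it also remains open whether the chlorine itself matters, which a plain methyl or a bromomethyl on the carbonyl carbon would test, and whether the gain holds with a carboxylic acid in place of the ethyl ester.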